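Working notes on a methyl step from compound 2 to compound 3

The source may hold more compounds than are shown below. What is called first, only, known or untested is meant among the compounds shown, and "the series" means these compounds.

Two compounds are measured in a functional assay on MIA PaCa-2 cells (Homo sapiens) for cytotoxicity, read by MTT assay, with a stated time of 72 h; a lower number here means a stronger inhibitor, a higher number a weaker inhibitor. Compound 1 `Cc1cn(C/C=C\CNC(=O)c2ccccc2)c(=O)[nH]c1=O` reaches only a limit there; in this assay compound 1 gives > 100000 nM. Compound 2 `O=C(NC/C=C\Cn1ccc(=O)[nH]c1=O)c1ccc(F)cc1` likewise stops at a limit, and in this assay compound 2 gives > 100000 nM. Both measured values sit at the limit of > 100000 nM in this assay, at which 2 of the 2 values shown sit. Compound 3 `Cc1cn(C/C=C\CNC(=O)c2ccc(F)cc2)c(=O)[nH]c1=O` differs from compound 2 by methyl in place of hydrogen on an aromatic carbon. Going by the values given here, no step between measured compounds exists; compound 1 already carries this methyl and stays at the limit. Compound 3 is therefore expected to stay at the limit too, a step that the limit leaves unreadable from compound 2 to compound 3. The estimate for compound 3 is 150000 nM, between 50000 nM and 500000 nM.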

Compound 3, half-maximal inhibitory concentration: > 100000 nM
Compound 3 was reported as a limit; the forecaster's own chance of this, stated with the estimate: 85%; the middle value does not contradict the limit.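

Going by these compounds alone, no step to compound 3 can be read from compound 1 or compound 2, because all three stop at a limit: the limit of > 100000 nM in this assay, at which 3 of the 3 values shown sit. The compounds shown leave open whether methyl or fluoro in place of hydrogen changes cytotoxicity at all.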